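Aryl variation on the aromatic nitrogen of the shared core

The source may report more compounds than this note shows. Statements on the series, on what has been measured and on what is new or still open speak of the compounds shown alone.

Among the compounds with values here, compound 3 `O=C(NO)c1ccc(NCc2nc(-c3ccccc3)nn2-c2ccc(C(F)(F)F)cc2)cc1` gives 38.9% in an assay on Sf9 cells for inhibition of protein deacetylase HDAC6 (Homo sapiens), read by fluorescence, with a stated time of 40 min, tested at 100 nM (on this read-out lower numbers stand for less inhibition and higher numbers for more inhibition at the one concentration tested (going by the name of the read-out)), the lowest of the three numbers measured so far. Compound 1 `Cc1cccc(-n2nc(-c3ccccc3)nc2CNc2ccc(C(=O)NO)cc2)c1` gives 66% and compound 2 `COc1ccc(-n2nc(-c3ccccc3)nc2CNc2ccc(C(=O)NO)cc2)cc1` gives 63.4%; these two sit within the scatter of each other (a number 2.6 percentage points lower from compound 1 to compound 2 (within the scatter)). Compound 4 `Cc1ccc(-n2nc(-c3ccccc3)nc2CNc2ccc(C(=O)NO)cc2)cc1C` differs from compound 3 by 3,4-dimethylphenyl in place of 4-(trifluoromethyl)phenyl on an aromatic nitrogen. Within the data shown here, two measured steps bear on this change: a number 27.1 percentage points lower from compound 1 to compound 3 (beyond the scatter) and a number 24.5 percentage points lower from compound 2 to compound 3 (beyond the scatter). Both exchange a 3-methylphenyl or 4-methoxyphenyl for the 4-(trifluoromethyl)phenyl and both fall by a modest amount beyond the scatter. The change to compound 4 runs the other way, so a modest rise is expected, a number 25.1 percentage points higher from compound 3 to compound 4 (beyond the scatter). Compound 4 is therefore estimated at 64%, with a range from 48% to 78%.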

Compound 4, a percentage reported as inhibition, at one concentration (the size of the read-out at that concentration, not a potency): 53%
Beside the measured number, compound 4's estimate is 11 percentage points above it, and the stated range covers the measured number.
By their numbers in this assay, from the lowest: compound 3; then compound 4; then compounds 2 and 1 (each within the scatter of the next).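

In this assay, adding a methyl to the aryl ring of compound 1 does not hold its level: a number 13 percentage points lower from compound 1 to compound 4 (beyond the scatter). The 3,4-dimethylphenyl group takes an intermediate place, with a number 14.1 percentage points higher from compound 3 to compound 4 (beyond the scatter) and a number 10.4 percentage points lower from compound 2 to compound 4 (beyond the scatter), so these four aryl groups give three levels rather than a split into two. No measured evidence bears on these steps.

Still open, going by these compounds, is how this position responds to an aryl ring carrying an amine or a carboxylic acid. A cyclohexyl group in place of the aryl ring also remains to be placed.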